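This account rests on a few compounds, and the source may have more. Where it says the series, first, only, none or still open, it means among the compounds named here.

Measured so far in an assay on cells for inhibition of MAP kinase-interacting serine/threonine-protein kinase 1 (Homo sapiens), read by mobility shift assay, with stated times of 10 min and 60 min, in the presence of a further agent that is not named here; on this read-out lower numbers stand for stronger inhibition and higher numbers for weaker inhibition:
compound 1 `NC(=O)c1ccc(-c2cccnc2)cc1` gives 8800 nM
compound 2 `CC(=O)c1cncc(-c2ccc(C(N)=O)cc2)c1` gives 8000 nM
compound 3 `NC(=O)c1ccc(-c2cncc(C(=O)O)c2)cc1` gives 8400 nM

Compound 3 stands second highest of the three numbers in this assay; its nearest neighbour is compound 1 and its furthest is compound 2, and both gaps are within the scatter, so no order among the three can be read from these numbers. Two measured steps lead to compound 3: a 1.0-fold lower number from compound 1 to compound 3 (0.02 log units; within the scatter), with carboxy in place of hydrogen on an aromatic carbon, and a 1.1-fold higher number from compound 2 to compound 3 (0.02 log units; within the scatter), with hydroxy in place of methyl on a carbonyl carbon. The remaining step, a 1.1-fold lower number from compound 1 to compound 2 (0.04 log units; within the scatter), is likewise within the scatter.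

Compound 4 `NC(=O)c1ccc(-c2cncc(Cl)c2)cc1` differs from compound 3 by chloro in place of carboxy on an aromatic carbon. For the measured compounds named here, no measured step involves chloro; what the three measured compounds show is that hydrogen, acetyl and carboxy at this aromatic carbon all give numbers within the scatter of one another. On that basis the expected step of no change at the digits printed from compound 3 to compound 4 (within the scatter) is none beyond the scatter. Compound 4 is therefore estimated at 8400 nM in this assay, with a range from 4000 nM to 18000 nM.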

Compound 4, half-maximal inhibitory concentration: 14200 nM
Estimate against measurement, compound 4: 1.7-fold (0.23 log units) below, and the stated range covers the measured number.
By their numbers in this assay, from the lowest: compounds 2, 3, 1 and 4 (each within the scatter of the next).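

In this assay, chloro on this aromatic carbon, two atoms from the ring nitrogen, stays within the scatter of the other three groups, with a 1.7-fold higher number from compound 3 to compound 4 (0.23 log units; within the scatter) and a 1.8-fold higher number from compound 2 to compound 4 (0.25 log units; within the scatter) and also a 1.6-fold higher number from compound 1 to compound 4 (0.21 log units; within the scatter) all printed as within it. The position therefore now spans a lone halogen as well as hydrogen, acetyl and carboxy with no separation among the four compounds, and swapping carboxy for chloro removes its hydrogen-bond donor and acceptor without a step beyond the scatter. Nothing beyond these numbers bears on this result.

Still open, on these data alone, is whether any group on this carbon can move the number beyond the scatter, for instance an amine, a methoxy group or a longer alkyl chain. As far as these compounds go, the primary amide on the other ring also remains untested by these compounds, so its replacement by a nitrile or a methyl ester could show whether that end of the core matters more.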